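The compounds below may be only part of what the source reports. "The series", "measured", "known", "first", "only" and "open" are said of these compounds alone.

Measured compounds:
compound 1, `COCCNC(=O)c1n[nH]cc1NC(=O)c1c(OC)cccc1OC` — > 50000 nM
compound 2, `CO[C@H]1CC[C@H](NC(=O)c2n[nH]cc2NC(=O)c2ccc(OC(F)F)cc2)CC1` — 2500 nM

Compound 1 stands at the edge of what an ADME assay on MRC5 cells (Homo sapiens) for inhibition, with a stated time of 72 h (on this read-out lower numbers stand for an effect already at smaller amounts and higher numbers for an effect only at larger amounts of compound), can report. In this assay compound 1 gives > 50000 nM, which is a limit of the assay and not a measured number. Compound 2 gives 2500 nM in this assay, a measured number. The change from compound 1 to compound 3, `COc1cccc(OC)c1C(=O)Nc1c[nH]nc1C(=O)Nc1ccccn1`, is pyridin-2-yl in place of 2-methoxyethyl on an amide-type nitrogen. Among the measured compounds shown here, no step between two measured compounds is available here, so the size of the step can only be expected, not read off; a small move or none beyond the usual scatter is expected for an at least 1.4-fold lower number from compound 1 to compound 3 (0.15 log units; that floor lies within the scatter), with a fair chance that compound 3 also stays at the cutoff, given (the limit of > 50000 nM in this assay, at which 1 of the 2 values shown sits). Compound 3 is estimated at 35000 nM, within the range 8000 nM to 100000 nM.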

Compound 3, half-maximal effective concentration: > 50000 nM
Compound 3 ended at the assay's limit; the forecaster's own chance of this, stated with the estimate: 55%; middle value at least 1.4-fold (0.15 log units) from the limit.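

No step can be read from compound 1 to compound 3, as both values in this assay are limits of the assay and not measured numbers: the limit of > 50000 nM in this assay, at which 2 of the 3 values shown sit.

The compounds shown leave open what pyridin-2-yl in place of 2-methoxyethyl on an amide-type nitrogen does to the read-out in this assay.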